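Cyclohexyl for tert-butyl on the sulfonamide nitrogen

A few compounds are considered here, and "the series" means these few. Any claim that something is new, unique, unknown or untested is made for them only; others in the source may bear on it.

Compound 1 `CC(C)NS(=O)(=O)NC(=O)Nc1c(C(C)C)cccc1C(C)C`: 18000 nM
Compound 2 `CC(C)c1cccc(C(C)C)c1NC(=O)NS(=O)(=O)N(C(C)C)C(C)(C)C`: 140 nM

In an assay on liver for inhibition of sterol O-acyltransferase 1 (Rattus norvegicus), using microsomes (a lower number here means a stronger inhibitor, a higher number a weaker inhibitor), compound 2 gives 140 nM, the lowest of the two numbers; compound 1 gives 18000 nM. Compound 3 `CC(C)c1cccc(C(C)C)c1NC(=O)NS(=O)(=O)N(C(C)C)C1CCCCC1` differs from compound 2 by cyclohexyl in place of tert-butyl on a sulfonamide nitrogen. For the measured compounds named here, the only measured step, a 130-fold lower number from compound 1 to compound 2 (2.11 log units; beyond the scatter), concerns a different change, so nothing directly bears on this one. The step from compound 2 to compound 3 is expected to stay within the scatter, a 1.2-fold lower number from compound 2 to compound 3 (0.07 log units; within the scatter). For compound 3 the estimate in this assay is 120 nM, between 40 nM and 400 nM.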

Compound 3, half-maximal inhibitory concentration: 360 nM
Compound 3: the middle estimate sits 3.0-fold (0.48 log units) below what was measured; the range from low to high includes it.
By their numbers in this assay, from the lowest: compound 2; then compound 3; then compound 1.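

In this assay cyclohexyl in place of tert-butyl on a sulfonamide nitrogen gives a 2.6-fold higher number from compound 2 to compound 3 (0.41 log units; beyond the scatter) and so brings a modest loss, showing that this position can hold a six-membered ring with only a limited penalty. Cyclohexyl in place of hydrogen gives a 50-fold lower number from compound 1 to compound 3 (1.70 log units; beyond the scatter) and so keeps most of the large gain, which therefore does not depend on tert-butyl alone. From the compounds shown here alone, whether cyclopentyl, or a group carrying an amine or a carboxylic acid, would do better remains open. Nothing available explains why cyclohexyl and tert-butyl differ.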